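A few compounds are considered here, and "the series" means these few. Any claim that something is new, unique, unknown or untested is made for them only; others in the source may bear on it.

Compound 1 `Nc1cc(N)c2nc(-c3ccccc3)c(NCc3ccc(Cl)c(Cl)c3)nc2c1`: 31600 nM
Compound 2 `COc1cc(CNc2nc3cc(N)cc(N)c3nc2-c2ccccc2)cc(OC)c1OC`: 18200 nM
Compound 3 `COc1ccc(Sc2nc3cc(N)cc(N)c3nc2-c2ccccc2)cc1`: reported only as a limit, < 100000 nM

Of the compounds shown here, three built on a shared core have been tested in a functional assay on OVCAR-3 cells (Homo sapiens) for inhibition, read by sulforhodamine B assay, with a stated time of 48 h; a lower number here means that less compound is tolerated, a higher number that more compound is tolerated. Compound 1 gives 31600 nM and compound 2 gives 18200 nM; these two values lie within the usual scatter of each other, so neither can be called stronger or weaker. For compound 3 this assay returns only a limit, < 100000 nM, and no number. That is all that is known of where compound 3 stands: the limit of < 100000 nM in this assay, at which 1 of the 3 values shown sits.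

Compound 4 `Nc1cc(N)c2nc(-c3ccccc3)c(Oc3ccc(F)cc3)nc2c1` has not yet been measured. It differs from compound 3 in one place: 4-fluorophenoxy in place of (4-methoxyphenyl)sulfanyl on an aromatic carbon. Among the measured compounds, none differs from another in a single place, so there is no measured step to lean on, and the starting point is itself only a limit. The step from the limit of compound 3 is expected to be a step that the limit leaves unreadable from compound 3 to compound 4. In this assay compound 4 is estimated at 30000 nM, with a likely range from 8000 nM to 100000 nM.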

Compound 4, concentration lethal to 50% of the cells: < 100000 nM
Compound 4 gave a limit, no number; the forecaster's own chance of this, stated with the estimate: 30%; the middle value lies beyond the limit too.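

Compound 3 and compound 4 each return only a limit in this assay, so no step between them can be read: the limit of < 100000 nM in this assay, at which 2 of the 4 values shown sit.

The compounds shown leave open whether 4-fluorophenoxy in place of (4-methoxyphenyl)sulfanyl on this aromatic carbon changes the read-out at all.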